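The source may report more compounds than this note shows. Statements on the series, on what has been measured and on what is new or still open speak of the compounds shown alone.

In a functional assay on A549 cells (Homo sapiens) for cytotoxicity (a higher number here means that more compound is needed for the effect, a lower number that less compound is needed), three compounds with a shared core give closely grouped numbers: compound 1 `COC1=C(C)C(=O)/C(=C(O)/C=C/c2ccccc2OC)C(=O)C1(C)C` gives 2.4 ug/mL, compound 2 `COC1=C(C)C(=O)/C(=C(O)/C=C/c2ccc(O)cc2)C(=O)C1(C)C` gives 3.1 ug/mL and compound 3 `COC1=C(C)C(=O)/C(=C(O)/C=C/c2ccc(C)cc2)C(=O)C1(C)C` gives 4.3 ug/mL. Compound 3 therefore does not stand apart from the other two. The two steps that reach it are a 1.8-fold higher number from compound 1 to compound 3 (0.25 log units; within the scatter) and a 1.4-fold higher number from compound 2 to compound 3 (0.14 log units; within the scatter), and neither exceeds the scatter.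

Compound 4 `COC1=C(C)C(=O)/C(=C(O)/C=C/c2c(C)cccc2C)C(=O)C1(C)C` differs from compound 3 at one place, on a double-bonded chain carbon bound to a double-bonded chain carbon: 2,6-dimethylphenyl in place of 4-methylphenyl on a double-bonded chain carbon bound to a double-bonded chain carbon. Among the compounds with values here, no measured compound carries 2,6-dimethylphenyl, so this group has not been tested directly. The closest evidence is the set of earlier exchanges at that same place, namely a 1.8-fold higher number from compound 1 to compound 3 (0.25 log units; within the scatter) and a 1.3-fold higher number from compound 1 to compound 2 (0.11 log units; within the scatter), both small and within the scatter. The expected change is therefore no step beyond the scatter, estimated as a 1.2-fold lower number from compound 3 to compound 4 (0.09 log units; within the scatter). For compound 4 the estimated value is 3.5 ug/mL, with an expected range from 1.6 ug/mL to 7.5 ug/mL.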

Compound 4, concentration for half-maximal effect: 8.3 ug/mL
The estimate for compound 4 lay 2.4-fold (0.38 log units) below the measured number, and the stated range ends below it.
By their numbers in this assay, from the lowest: compounds 1, 2, 3 and 4 (each within the scatter of the next, the first and the last beyond it).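

In this assay, the step of a 1.9-fold higher number from compound 3 to compound 4 (0.29 log units; within the scatter) stays within the scatter, but a 2.7-fold higher number from compound 2 to compound 4 (0.43 log units; beyond the scatter) and a 3.5-fold higher number from compound 1 to compound 4 (0.54 log units; beyond the scatter) both pass beyond it, though only modestly. Within the data shown here, these are the first exchanges at this place, on a double-bonded chain carbon bound to a double-bonded chain carbon, to exceed the scatter, so the group here can make a measurable, if small, difference to the number, and 2,6-dimethylphenyl is the group that shows this. No measurement shown here offers an explanation for that difference.

Every compound shown carries a substituted phenyl at this place. As far as these compounds go, what an unsubstituted phenyl, or a phenyl bearing an amine or a carboxylic acid, would give in this assay remains open, as does whether any such group would produce a larger step.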